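Removing a ring methyl from a potent aldosterone synthase inhibitor

The compounds below may be only part of what the source reports. "The series", "measured", "known", "first", "only" and "open" are said of these compounds alone.

Compound 1 `CCC(=O)N[C@@H]1CCCc2c1cncc2N1C(=O)c2ccc(Cl)cc2[C@@H]1C` is measured in an assay on cells for inhibition of cytochrome P450 11B2, mitochondrial (Homo sapiens), read by HTRF (a higher number here means a weaker inhibitor, a lower number a stronger inhibitor), where compound 1 gives 6 nM. Among the three compounds with numbers, compound 1 stands second highest. Its closest neighbour is compound 2 `CC(=O)N[C@@H]1CCCc2c1cncc2N1C(=O)c2ccc(Cl)cc2[C@@H]1C`, which gives 4 nM; the step of a 1.5-fold lower number from compound 1 to compound 2 (0.18 log units; within the scatter) exchanges a propanamide for an acetamide on the amide chain and is within the scatter. Far away stands compound 3 `O=C1c2ccccc2CN1c1cccnc1`, a small fragment that gives 1120 nM; it lacks the amide-bearing saturated ring and the chloro substituent, and no single step connects it to compound 1.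

Compound 4 `CCC(=O)N[C@@H]1CCCc2c1cncc2N1Cc2cc(Cl)ccc2C1=O` differs from compound 1 by hydrogen in place of methyl on a saturated ring carbon, on the five-membered non-aromatic ring with one nitrogen, next to the ring nitrogen and next to the ring atom that bears a large group. Within the data shown here, no measured step touches this position, so the only guidance is indirect: the one step that is measured, on the amide chain, was within the scatter, while stripping the core down to compound 3 changes the number greatly. Taking out a single methyl is far closer to the first than to the second, so compound 4 is expected to stay potent, with a modest rise in this assay of a 2.5-fold higher number from compound 1 to compound 4 (0.40 log units; beyond the scatter). The estimate for compound 4 is 15 nM, expected to fall between 4 nM and 60 nM.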

Compound 4, half-maximal inhibitory concentration: 28 nM
Compound 4: the middle estimate sits 1.9-fold (0.27 log units) below what was measured; the range from low to high includes it.
By their numbers in this assay, from the lowest: compounds 2 and 1 (each within the scatter of the next); then compound 4; then compound 3.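

In this assay, the methyl on this saturated ring carbon makes a measurable difference: removing it gives a 4.7-fold higher number from compound 1 to compound 4 (0.67 log units; beyond the scatter). The only earlier step, on the amide chain, was a 1.5-fold lower number from compound 1 to compound 2 (0.18 log units; within the scatter), so this ring carbon is the first place shown where a small change moves the number beyond the usual scatter, although compound 4 still gives 28 nM, so some potency is lost but far from all. Nothing available explains why this position responds in this way.

The compounds shown leave open what an ethyl group, a hydroxymethyl group or a second methyl would do on this same ring carbon. They also leave open whether taking out the methyl would cost a similar amount when the amide chain is the acetamide of compound 2.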